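A few compounds are considered here, and "the series" means these few. Any claim that something is new, unique, unknown or untested is made for them only; others in the source may bear on it.

Among the measured compounds shown here, compound 2 `O=C(O)c1csc(SCCN2C(=O)CC[C@@H]2/C=C/[C@@H](O)Cc2cccc(-c3nc4ccccc4o3)c2)n1` stands as the higher of the two numbers so far in an assay on CHO cells for displacement of a labelled ligand from prostaglandin E2 receptor EP2 subtype (Mus musculus), read by scintillation counting, with a stated time of 60 min; on this read-out higher numbers stand for weaker inhibition and lower numbers for stronger inhibition: compound 2 gives 28 nM, whereas compound 1 `O=C(O)c1csc(SCCN2C(=O)CC[C@@H]2/C=C/[C@@H](O)Cc2cccc(-c3ccccc3)c2)n1` gives 3 nM. For the measured compounds named here, the single measured step, a 9.3-fold higher number from compound 1 to compound 2 (0.97 log units; beyond the scatter), came with 1,3-benzoxazol-2-yl in place of phenyl on an aromatic carbon. Compound 3 `Cc1ccc2oc(-c3cccc(C[C@H](O)/C=C/[C@H]4CCC(=O)N4CCSc4nc(C(=O)O)cs4)c3)nc2c1` differs from compound 2 by methyl in place of hydrogen on an aromatic carbon; cut one bond further out, this reads 1,3-benzoxazol-2-yl to 5-methyl-1,3-benzoxazol-2-yl. Going by the values given here, no measured step concerns a methyl on the fused ring: the step from compound 1 to compound 2 exchanged the whole phenyl and does not bear on this change. With nothing in the series to guide the direction, the expected step, no change at the digits printed from compound 2 to compound 3 (within the scatter), is none beyond the scatter. Compound 3 is therefore estimated at 28 nM, with a range of 9 nM to 90 nM.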

Compound 3, inhibition constant: 21 nM
The estimate for compound 3 lay 1.3-fold (0.12 log units) above the measured number; the range from low to high includes it.
By their numbers in this assay, from the lowest: compound 1; then compounds 3 and 2 (each within the scatter of the next).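

In this assay, methyl in place of hydrogen on the carbon-only six-membered ring of the 1,3-benzoxazol-2-yl group leaves the reading within the scatter, with a 1.3-fold lower number from compound 2 to compound 3 (0.12 log units; within the scatter). Among the compounds shown here, this is the first sign that this fused ring accepts a small addition at this place without a change that can be read, while the gap to the phenyl compound stays beyond the scatter, with a 7.0-fold higher number from compound 1 to compound 3 (0.85 log units; beyond the scatter). Nothing available explains either step.

On these data alone, it remains open whether a larger or differently built group at the same place, such as a methoxy, an amine or a carboxylic acid, would also leave the number within the scatter. Also open, as far as these compounds go, is whether a single-ring replacement for the fused group, such as a pyridine or an oxazole, would come closer to compound 1.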